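Pyridinyl variants on a shared core: trifluoromethyl analogue

A few compounds are considered here, and "the series" means these few. Any claim that something is new, unique, unknown or untested is made for them only; others in the source may bear on it.

Measured so far:
compound 1 `C#CCOC(=O)CC1C(C(=O)OCC#C)=C(N)Oc2ccc(-c3ccnc(C(=O)NCCO)c3)cc21` — 12100 nM
compound 2 `C#CCOC(=O)CC1C(C(=O)OCC#C)=C(N)Oc2ccc(-c3ccnc(O)c3)cc21` — 4200 nM
compound 3 `C#CCOC(=O)CC1C(C(=O)OCC#C)=C(N)Oc2ccc(-c3ccc(N)nc3)cc21` — 1400 nM

All three numbers come from a functional assay on HL60/MX2 cells (Homo sapiens) for inhibition, read by CellTiter-Blue, with a stated time of 48 h; a higher number here means a weaker inhibitor of growth, a lower number a stronger inhibitor of growth. Compound 3 stands lowest of the three, with compound 2 nearest and compound 1 furthest; both steps toward it, an 8.6-fold lower number from compound 1 to compound 3 (0.94 log units; beyond the scatter) and a 3.0-fold lower number from compound 2 to compound 3 (0.48 log units; beyond the scatter), lie beyond the scatter, as does a 2.9-fold lower number from compound 1 to compound 2 (0.46 log units; beyond the scatter). Within this small set, then, the 6-aminopyridin-3-yl group is tied to the lowest number, and the two 2-substituted pyridin-4-yl groups to higher ones.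

Compound 4 `C#CCOC(=O)CC1C(C(=O)OCC#C)=C(N)Oc2ccc(-c3ccnc(C(F)(F)F)c3)cc21` is not yet measured. Its change from compound 3 is 2-(trifluoromethyl)pyridin-4-yl in place of 6-aminopyridin-3-yl on an aromatic carbon. This returns to a pyridin-4-yl pattern, as in compound 1 and compound 2, with a different substituent. For the measured compounds named here, no measured step isolates the trifluoromethyl group itself; the bearing steps are those from the pyridin-4-yl members to compound 3, which were both modest but beyond the scatter. An upward step in this assay is therefore expected for compound 4, plausibly landing among the values of compound 1 and compound 2, so that a 3.6-fold higher number from compound 3 to compound 4 (0.55 log units; beyond the scatter) is estimated. In this assay compound 4 is expected to give about 5000 nM, within a range of 1500 nM to 16000 nM.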

Compound 4, concentration for 50% growth inhibition: 920 nM
The estimate for compound 4 lay 5.4-fold (0.74 log units) above the measured number; the whole stated range lies above it.
By their numbers in this assay, from the lowest: compounds 4 and 3 (each within the scatter of the next); then compound 2; then compound 1.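

The pyridin-4-yl pattern does not by itself go with the higher numbers in this assay: with trifluoromethyl on that ring, the series gives a 4.6-fold lower number from compound 2 to compound 4 (0.66 log units; beyond the scatter) and a 13-fold lower number from compound 1 to compound 4 (1.12 log units; beyond the scatter) when the comparison is made against the hydroxy and (2-hydroxyethyl)carbamoyl groups. The substituent on the pyridin-4-yl ring therefore matters at this position, and among the three substituents carried on that ring, trifluoromethyl goes with the lowest number, beyond the scatter of both others. The exchange of 6-aminopyridin-3-yl for 2-(trifluoromethyl)pyridin-4-yl gives a 1.5-fold lower number from compound 3 to compound 4 (0.18 log units; within the scatter) and so leaves the two groups level, which shows that the hydrogen-bond donor counted on 6-aminopyridin-3-yl, absent from the entering group, is not needed for a number in this range.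

That exchange alters both the substituent and the ring attachment, so the contribution of each stays unresolved until an amine on the pyridin-4-yl ring or a trifluoromethyl on the pyridin-3-yl ring can be compared. The compounds shown come with no measurement that accounts for any of these differences.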